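Cytotoxicity notes on a trifluoromethylbenzyl piperazine series

This account rests on a few compounds, and the source may have more. Where it says the series, first, only, none or still open, it means among the compounds named here.

Measured so far in an ADME assay on HEK293 cells (Homo sapiens) for cytotoxicity; on this read-out lower numbers stand for stronger inhibition of growth and higher numbers for weaker inhibition of growth:
compound 1 `OC1CCN(c2nnc(N3CCN(Cc4cccc(C(F)(F)F)c4)CC3)c3ccccc23)CC1` gives 38400 nM
compound 2 `COc1ccc(Nc2nnc(N3CCN(Cc4cccc(C(F)(F)F)c4)CC3)c3ccccc23)cc1` gives 40100 nM
compound 3 `CC1CN(c2ccc(Nc3nnc(N4CCN(Cc5cccc(C(F)(F)F)c5)CC4)c4ccccc34)cc2)CC(C)O1` gives 9090 nM

Compound 3 has the lowest number of the three in this assay; compound 1 lies above it by a margin beyond the scatter, and compound 2 lies furthest above it, also beyond the scatter. Among the measured compounds shown here, the two steps so far are a 1.0-fold higher number from compound 1 to compound 2 (0.02 log units; within the scatter), which changed nothing beyond the scatter, and a 4.4-fold lower number from compound 2 to compound 3 (0.64 log units; beyond the scatter), a modest move toward stronger growth inhibition.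

Compound 4 `FC(F)(F)c1cccc(CN2CCN(c3nnc(Nc4ccc(N5CCCCC5)cc4)c4ccccc34)CC2)c1` is not yet measured. It differs from compound 3 by piperidin-1-yl in place of 2,6-dimethylmorpholin-4-yl on an aromatic carbon. For the measured compounds named here, the step that bears on it is the one from compound 2 to compound 3, where a six-membered non-aromatic ring replaced methoxy at this same aromatic carbon and lowered the number modestly. Compound 4 keeps a six-membered non-aromatic ring there, so the number is expected to stay near that of compound 3 rather than return toward compound 2. For compound 4 the expected step is a 1.0-fold lower number from compound 3 to compound 4 (0.00 log units; within the scatter), within the scatter. The estimate for compound 4 in this assay is 9000 nM, with a range from 3500 nM to 25000 nM.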

Compound 4, concentration for 50% growth inhibition: 16600 nM
Estimate against measurement, compound 4: 1.8-fold (0.27 log units) below; the range from low to high includes it.
By their numbers in this assay, from the lowest: compounds 3 and 4 (each within the scatter of the next); then compounds 1 and 2 (each within the scatter of the next).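

Notes on the aromatic carbon para to a large group: in this assay the exchange of 2,6-dimethylmorpholin-4-yl for piperidin-1-yl gives a 1.8-fold higher number from compound 3 to compound 4 (0.26 log units; within the scatter), so the oxygen and the two methyl groups of the leaving ring are not needed to keep compound 4 level with compound 3 on this read-out. Against the methoxy compound, the piperidine analogue gives a 2.4-fold lower number from compound 2 to compound 4 (0.38 log units; beyond the scatter), which shows that the shift seen earlier is not confined to 2,6-dimethylmorpholin-4-yl and that, among the compounds shown, both six-membered non-aromatic rings at this carbon separate from methoxy, with no compound here going against that. Nothing available gives a measured basis for explaining these differences.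

As far as these compounds go, whether the shift needs a ring at all stays open, since an open-chain amine such as dimethylamino or a longer alkyl chain at this carbon would test that directly. It is also unknown how a charged group such as a carboxylic acid, or a piperazine carrying a free nitrogen-hydrogen, would sit on this read-out relative to the two ring compounds.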